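Bromo on the phenylsulfonyl group of compound 3

A few compounds are considered here, and "the series" means these few. Any claim that something is new, unique, unknown or untested is made for them only; others in the source may bear on it.

Measured compounds:
compound 1 `O=C1/C(=C/c2cccnc2)CN(S(=O)(=O)c2ccccc2)C/C1=C\c1ccccc1F` gives 4800 nM
compound 2 `Cc1ccc(S(=O)(=O)N2C/C(=C\c3ccncc3)C(=O)/C(=C/c3ccccc3F)C2)cc1` gives > 20000 nM
compound 3 `O=C1/C(=C/c2cccnc2)CN(S(=O)(=O)c2ccccc2)C/C1=C\c1ccccc1C(F)(F)F` gives 6240 nM

In a functional assay on QGY-7703 cells (Homo sapiens) for cytotoxicity, read by MTT assay, with a stated time of 24 h (on this read-out lower numbers stand for stronger inhibition and higher numbers for weaker inhibition), compound 3 gives 6240 nM and sits within the scatter of compound 1 with its 4800 nM reading. For compound 2 the entry > 20000 nM is a limit of the assay and not a number.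

Compound 4 `O=C1/C(=C/c2cccnc2)CN(S(=O)(=O)c2ccc(Br)cc2)C/C1=C\c1ccccc1C(F)(F)F` carries one change from compound 3: bromo in place of hydrogen on an aromatic carbon that is, bromo in place of hydrogen on an aromatic carbon, para to a large group, so that phenylsulfonyl becomes (4-bromophenyl)sulfonyl.

Among the compounds with values here, the only measured step that changes a single place is a 1.3-fold higher number from compound 1 to compound 3 (0.11 log units; within the scatter) and it puts trifluoromethyl in place of fluoro, which is a different change. Within the data shown here, no measured step alters the phenylsulfonyl group, so the guidance here is thin. Among the measured compounds shown here, with only that small step to go on, no shift beyond the scatter is expected in this assay in either direction. The expected move is a 1.1-fold lower number from compound 3 to compound 4 (0.05 log units; within the scatter) and it remains a modest estimate. Compound 4 is expected at 5500 nM with an estimated range from 2000 nM to 15000 nM as its likely span.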

Compound 4, half-maximal inhibitory concentration: 5510 nM
Compound 4: the middle estimate sits 1.0-fold (0.00 log units) below what was measured; the measured number falls inside the stated range.
By their numbers in this assay, from the lowest: compounds 1, 4 and 3 (each within the scatter of the next). At a limit, above all of these: compound 2.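

In this assay, bromo in place of hydrogen on an aromatic carbon, para to a large group, gives a 1.1-fold lower number from compound 3 to compound 4 (0.05 log units; within the scatter). This is the first look at the phenylsulfonyl group among the compounds shown, and it indicates that adding one bromine atom at this position leaves the reading within the scatter. The earlier single-place change, a 1.3-fold higher number from compound 1 to compound 3 (0.11 log units; within the scatter), was made elsewhere in the molecule, so it could say nothing about this position, and compound 2 differs from the others in more than one place, with an entry that is a limit of the assay and not a number, so no step to it can be read: the limit of > 20000 nM in this assay, at which 1 of the 4 values shown sits.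

One substituent at one position is a narrow test, and it cannot show whether bromo would leave the reading just as unmoved in compound 1, which carries fluoro in place of trifluoromethyl. On these data alone, it also remains open whether an amine or a carboxylic acid on this same carbon would stay within the scatter of compound 3 or move the number clearly.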